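Adding One Chain Carbon at the Assay Limit

The compounds below may be only part of what the source reports. "The series", "measured", "known", "first", "only" and "open" are said of these compounds alone.

In a functional assay on A549 cells (Homo sapiens) for inhibition, read by sulforhodamine B assay, with a stated time of 48 h (a higher number here means a weaker inhibitor, a lower number a stronger inhibitor), compound 1 `O=C(CCCC(=O)Nc1ccc(NC(=O)Nc2ccc(Cl)c(C(F)(F)F)c2)cc1)NO` gives > 10000 nM, which is a limit of the assay and not a number. Compound 2 `O=C(CCCCC(=O)Nc1ccc(NC(=O)Nc2ccc(Cl)c(C(F)(F)F)c2)cc1)NO` gives > 10000 nM, which is also only a limit. Compound 2 therefore has no exact place on the scale, and the whole record so far reads: the limit of > 10000 nM in this assay, at which 2 of the 2 values shown sit.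

Compound 3 `O=C(CCCCCC(=O)Nc1ccc(NC(=O)Nc2ccc(Cl)c(C(F)(F)F)c2)cc1)NO` differs from compound 2 by a single change that extends the chain: (hydroxycarbamoyl)methyl in place of hydroxycarbamoyl on a saturated chain carbon, four bonds along the chain from a carbonyl carbon. Here (hydroxycarbamoyl)methyl takes the place of hydroxycarbamoyl, four bonds along the chain from a carbonyl carbon.

For the measured compounds named here, the only measured step that bears on this is the same replacement made three bonds along the chain, and it is a step that the two limits leave unreadable from compound 1 to compound 2. It gives no size to carry forward, so only a modest move toward a stronger inhibitor is expected in this assay, if there is any move at all. The expected size of this step is an at least 1.1-fold lower number from compound 2 to compound 3 (0.04 log units; that floor lies within the scatter). Compound 3 is estimated at 9000 nM, with an expected range of 2500 nM to 30000 nM, and the assay may again report only a limit.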

Compound 3, half-maximal inhibitory concentration: > 10000 nM
Compound 3 ended at the assay's limit (the forecaster's own chance of this, stated with the estimate: 55%); middle value at least 1.1-fold (0.04 log units) away from the limit.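

In this assay compound 3 gives > 10000 nM, again a limit of the assay and not a number. For the compounds shown here, no step among compound 1, compound 2 and compound 3 can be read, and the record now stands as: the limit of > 10000 nM in this assay, at which 3 of the 3 values shown sit. How strongly each of these compounds inhibits, and whether chain length matters for it, remains open.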